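Bromo in Place of Hydrogen on the Aryl Ring

A few compounds are considered here, and "the series" means these few. Any claim that something is new, unique, unknown or untested is made for them only; others in the source may bear on it.

Of the compounds shown here, three that share one core have been measured in a physicochemical assay for lipophilicity, measured as octanol-water partition, at pH 7.4; on this read-out lower numbers stand for lower lipophilicity and higher numbers for higher lipophilicity. Compound 1 `c1ccc(NC2=NCCC3(CCCCC3)S2)cc1` gives 1.02. Compound 2 `CC(=O)c1cccc(NC2=NCCC3(CCCCC3)S2)c1` gives 2.37, and compound 3 `CNC1=NCCC2(CCCCC2)S1` gives 0.88. Among these three numbers compound 1 stands second highest: compound 3 sits nearest, and compound 2 furthest from it.

The step now followed leads from compound 1 to compound 4 `Brc1ccc(NC2=NCCC3(CCCCC3)S2)cc1`, which has not yet been measured in this assay. The change is bromo in place of hydrogen on an aromatic carbon.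

Among the compounds with values here, of the two measured steps, the one that bears most on this change is the one from compound 1 to compound 2, where a group entered on an aromatic carbon of the same ring and gave a number 1.35 log units higher from compound 1 to compound 2 (beyond the scatter). The step from compound 1 to compound 3, which gave a number 0.14 log units lower from compound 1 to compound 3 (within the scatter), touches the amine nitrogen rather than the ring and says little here.

Within the data shown here, because the only measured change on the aromatic ring gave a number 1.35 log units higher from compound 1 to compound 2 (beyond the scatter), a rise beyond the scatter is expected for compound 4 as well. The estimated step is a number 0.88 log units higher from compound 1 to compound 4 (beyond the scatter). Compound 4 is therefore expected to give about 1.9, within a range from 1.4 to 2.5.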

Compound 4, distribution coefficient: 2.53
The estimate for compound 4 lay 0.63 log units below the measured number; measured number above the stated range.
By their numbers in this assay, from the lowest: compounds 3 and 1 (each within the scatter of the next); then compounds 2 and 4 (each within the scatter of the next).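

In this assay, a single bromine atom on an aromatic carbon, para to a large group, accounts for a number 1.51 log units higher from compound 1 to compound 4 (beyond the scatter), which is a large step. The acetyl change on the same ring gave a number 1.35 log units higher from compound 1 to compound 2 (beyond the scatter), so both ring changes shown so far raise the number beyond the scatter, and the bromo does so with only one heavy atom and with 0 hydrogen-bond donors and 0 hydrogen-bond acceptors. No measurement at hand explains the size of the bromo step, so these numbers describe what happened at this position but not the reason for it.

The compounds shown leave open whether other groups on this same carbon would also raise the number so far, such as a chlorine or fluorine atom, a methyl group, an amine or a carboxylic acid. They also leave open whether bromo would give a similar step on another carbon of the ring, and whether it would do so on a core that carries the methyl group of compound 3 in place of the phenyl ring.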